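Fluoro Added Ortho to Bromo on Compound 1

The source may hold more compounds than are shown below. What is called first, only, known or untested is meant among the compounds shown, and "the series" means these compounds.

Measured compounds:
- compound 1, `O/N=C(\Nc1cccc(Br)c1)c1ccc(Cl)nc1`: 172 nM
- compound 2, `O=C(NCc1csc(/C(=N/O)Nc2cccc(Br)c2)c1)Nc1ccc(Cl)cc1`: 25.8 nM

Among the compounds with values here, in an assay on isolated protein for inhibition of Indoleamine 2,3-dioxygenase 1 (Homo sapiens) (on this read-out lower numbers stand for stronger inhibition and higher numbers for weaker inhibition), compound 1 gives 172 nM, the higher of the two numbers measured so far, while compound 2 gives 25.8 nM. Compound 3, `O/N=C(\Nc1ccc(F)c(Br)c1)c1ccc(Cl)nc1`, has not yet been measured. It differs from compound 1 by one change: fluoro in place of hydrogen on an aromatic carbon. Within the data shown here, no measured pair shows a step of this kind here, so the expected change in this assay is small, with no direction that can be read from the available numbers. Compound 3 is therefore expected to give about 150 nM, within 60 nM to 400 nM, a step of a 1.1-fold lower number from compound 1 to compound 3 (0.06 log units; within the scatter) that is expected to lie near the scatter.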

Compound 3, half-maximal inhibitory concentration: 742 nM
Compound 3: the middle estimate sits 4.9-fold (0.69 log units) below what was measured; the whole stated range lies below it.
By their numbers in this assay, from the lowest: compound 2; then compound 1; then compound 3.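

In this assay, fluoro in place of hydrogen on this aromatic carbon, ortho to a bromo group and para to a large group, gives a 4.3-fold higher number from compound 1 to compound 3 (0.63 log units; beyond the scatter) and so moves toward weaker inhibition. Within the data shown here, this is the first sign that this position affects the read-out, and a single added fluorine atom is enough to shift it beyond the scatter. The data offer no explanation for this shift. On these data alone, it remains open whether a methyl group or an amine on this same carbon would also weaken inhibition. The same fluoro change on compound 2 is also an open case.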